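The source may report more compounds than this note shows. Statements on the series, on what has been measured and on what is new or still open speak of the compounds shown alone.

Of the compounds shown here, two share one core and have been measured in a functional assay on Ehrlich cells (Mus musculus) for antiproliferative activity, read by trypan blue exclusion, with a stated time of 2 h, tested at 50 ug/mL; on this read-out lower numbers stand for a weaker effect and higher numbers for a stronger effect at the one concentration tested. Compound 1 `N#CC1=C(N)N(c2ccc(S(N)(=O)=O)cc2)C2=C(C(=O)CCC2)C1c1ccc(Cl)cc1Cl` gives 65% in this assay. Compound 2 `COc1ccc(C2C(C#N)=C(N)N(c3ccc(S(N)(=O)=O)cc3)C3=C2C(=O)CCC3)c2ccccc12`, which carries a different group on the same saturated ring carbon, gives 30%. For the measured compounds named here, the only step between them is a number 35 percentage points lower from compound 1 to compound 2 (beyond the scatter). On these two numbers compound 2 stands lowest, and its nearest neighbour, compound 1, lies well above it, beyond the scatter.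

Compound 3 `Cc1ccoc1C1C(C#N)=C(N)N(c2ccc(S(N)(=O)=O)cc2)C2=C1C(=O)CCC2` has not yet been measured. It differs from compound 2 in one place: 3-methylfuran-2-yl in place of 4-methoxynaphthalen-1-yl on a saturated ring carbon. Going by the values given here, the one measured step that bears on this change is the earlier swap at the same saturated ring carbon, a number 35 percentage points lower from compound 1 to compound 2 (beyond the scatter), which was large. Among the compounds with values here, that step shows the group at this carbon can move the read-out strongly, but no measured compound carries a 3-methylfuran-2-yl group, so a five-membered ring here has no precedent. A step of some size is therefore expected in this assay, more likely upward than downward because compound 2 sits at the low end with 30%, and the expected step is a number 18 percentage points higher from compound 2 to compound 3 (beyond the scatter). Compound 3 is estimated at 48%, with a range from 25% to 72%.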

Compound 3, a percentage reported as activity, at one concentration (the size of the read-out at that concentration, not a potency): 40%
Compound 3: the middle estimate sits 8 percentage points above what was measured; the range from low to high includes it.
By their numbers in this assay, from the lowest: compounds 2 and 3 (each within the scatter of the next); then compound 1.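

In this assay, replacing the two-ring 4-methoxynaphthalen-1-yl with the single-ring 3-methylfuran-2-yl on this saturated ring carbon gives a number 10 percentage points higher from compound 2 to compound 3 (within the scatter), so these two quite different groups cannot be told apart in this read-out. The 2,4-dichlorophenyl group of compound 1 stands clear of both, since the change to 3-methylfuran-2-yl gives a number 25 percentage points lower from compound 1 to compound 3 (beyond the scatter), alongside the earlier a number 35 percentage points lower from compound 1 to compound 2 (beyond the scatter); among these three compounds, then, a change at this carbon can shift the read-out strongly, but not every change does. No measurement is available that would explain why these groups compare as they do.

The compounds shown leave open whether the higher number of compound 1 depends on its two chlorine atoms or on the phenyl ring that carries them, a question that a plain phenyl or a 4-chlorophenyl group at this carbon could help to answer. Also open, on these data alone, is how groups of a different kind would behave at the same carbon, such as a carboxylic acid on a phenyl ring, an amine-bearing chain or a simple unbranched alkyl chain.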